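Adding a hydroxy group to compound 3

The compounds below may be only part of what the source reports. "The series", "measured", "known", "first", "only" and "open" are said of these compounds alone.

Values measured so far in an ADME assay on BJ cells (Homo sapiens) for cytotoxicity, read by MTT assay, with a stated time of 72 h; a higher number here means a weaker inhibitor, a lower number a stronger inhibitor
compound 1 `Oc1ccccc1CNc1ncnc2c1ncn2C1CCCCO1` gives > 100000 nM
compound 2 `Oc1cccc(CNc2ncnc3c2ncn3C2CCCCO2)c1` gives > 100000 nM
compound 3 `COc1cccc(CNc2ncnc3c2ncn3C2CCCCO2)c1` gives > 100000 nM

Compound 3 stands at > 100000 nM as a limit of the assay, not a number. The whole series offers only the limit of > 100000 nM in this assay, at which 3 of the 3 values shown sit, and no true reading. Compound 4 `COc1cccc(CNc2ncnc3c2ncn3C2CCCCO2)c1O` is compound 3 changed by hydroxy in place of hydrogen on an aromatic carbon with hydroxy in place of hydrogen on an aromatic carbon, ortho to a large group and ortho to a methoxy group. The measured steps that bear on this are a step that the two limits leave unreadable from compound 1 to compound 2 and a step that the two limits leave unreadable from compound 1 to compound 3 and a step that the two limits leave unreadable from compound 2 to compound 3 and none of them gives a size. Hydroxy and methoxy groups both occur among these three compounds, and neither gave a number. No step beyond the scatter is therefore expected in either direction. The expected step is a number no higher from compound 3 to compound 4 (the limit leaves the size open) on this thin evidence. For compound 4 the estimated value in this assay is 100000 nM with an expected range from 50000 nM to 200000 nM and a report at the limit is the likely outcome.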

Compound 4, half-maximal inhibitory concentration: > 100000 nM
Compound 4 gave a limit, no number; the forecaster's own chance of this, stated with the estimate: 85%; the middle value lies on the limit itself.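

Neither the step from compound 3 to compound 4 nor the step from compound 1 to compound 4 can be read, as compound 4, like compounds 1, 2 and 3, gives only a limit and no number: the limit of > 100000 nM in this assay, at which 4 of the 4 values shown sit. The compounds shown leave open whether a hydroxy or methoxy group on the aromatic ring changes cytotoxicity at all.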